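Dithiocarbamate benzamides: piperazine aryl swap

The compounds below may be only part of what the source reports. "The series", "measured", "known", "first", "only" and "open" are said of these compounds alone.

Compound 1 `COc1ccc(N2CCN(C(=S)SCc3ccc(C(=O)Nc4ccccc4N)cc3)CC2)cc1` is measured in a functional assay on HeLa cells (Homo sapiens) for antiproliferative activity, read by CCK-8 assay, with a stated time of 72 h, tested at 8 uM (a lower number here means a weaker effect, a higher number a stronger effect of the compound at the concentration tested), and gives 52.3%, the second highest of three numbers. Compound 2 `Nc1ccccc1NC(=O)c1ccc(CSC(=S)N2CCc3cc(Cl)ccc32)cc1` gives 65.1% in this assay, a higher number by a margin beyond the usual scatter, while compound 3 `Nc1ccccc1NC(=O)c1ccc(CSC(=S)N(Cc2ccccc2)Cc2ccccc2)cc1` gives 18.9%, well below compound 1. Compound 4 `Nc1ccccc1NC(=O)c1ccc(CSC(=S)N2CCN(c3ccncc3)CC2)cc1` has not been measured yet. It differs from compound 1 in one place: pyridin-4-yl in place of 4-methoxyphenyl on an amine nitrogen in a ring. Going by the values given here, no measured pair tracks this exchange, so there is no step to lean on; a small step in this assay, in either direction and likely within the scatter, is expected. The estimate for compound 4 is 45%, with a range from 25% to 65%. This expected estimate corresponds to a number 7.3 percentage points lower from compound 1 to compound 4 (within the scatter).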

Compound 4, a percentage reported as inhibition, at one concentration (the size of the read-out at that concentration, not a potency): 77.4%
The estimate for compound 4 lay 32.4 percentage points below the measured number; the measured number lies above the stated range.
By their numbers in this assay, from the lowest: compound 3; then compound 1; then compound 2; then compound 4.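

In this assay, the aryl group on the amine nitrogen in the ring proves to be a position that matters: pyridin-4-yl in place of 4-methoxyphenyl gives a number 25.1 percentage points higher from compound 1 to compound 4 (beyond the scatter) with nothing else changed. The counts of hydrogen-bond donors and acceptors and the net charge are the same for both groups. No measurement on hand accounts for the step.

From the compounds shown here alone, whether the gain tracks the ring nitrogen or the loss of the methoxy group remains open. Unsubstituted phenyl, pyridin-3-yl or pyridin-2-yl on the same nitrogen would separate the two.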